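The source may report more compounds than this note shows. Statements on the series, on what has been measured and on what is new or still open speak of the compounds shown alone.

Of the compounds shown here, three sharing one core have been tested in a functional assay on NCI-H460 cells (Homo sapiens) for antiproliferative activity, read by MTT assay, with a stated time of 48 h; on this read-out higher numbers stand for weaker inhibition and lower numbers for stronger inhibition: compound 1 (`CC(C)CCC1(O)C(=O)Nc2ccc(Nc3ccc(Cl)cc3)cc21`) gives 25000 nM, compound 2 (`CCCCC1(O)C(=O)Nc2ccc(Nc3ccc(C(F)(F)F)cc3)cc21`) gives 12000 nM, and compound 3 (`CCCCCC1(O)C(=O)Nc2ccc(Nc3ccc(C(F)(F)F)cc3)cc21`) gives 16300 nM. Compound 3 therefore stands within the usual scatter of both of the others, so its number cannot be told apart from either.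

Compound 4 (`CC(C)CCC1(O)C(=O)Nc2ccc(Nc3ccc(C(F)(F)F)cc3)cc21`) keeps the same atoms as compound 3 but joins them differently, turning the pentyl chain into an isopentyl chain: isopropyl in place of propyl on a saturated chain carbon, two bonds along the chain from a saturated ring carbon.

Two measurements bear on this change. Going by the values given here, the only measured step on the chain, between the butyl chain of compound 2 and the pentyl chain of compound 3, is small: a 1.4-fold higher number from compound 2 to compound 3 (0.13 log units; within the scatter). Compound 1 already carries the isopentyl chain, with chlorine where compound 3 and compound 4 carry trifluoromethyl, and compound 1 reads 25000 nM. Among the compounds with values here, no measured pair isolates branching on its own, so this is only indirect evidence. No step beyond the scatter is expected in this assay, though a slightly higher number would fit compound 1.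

The estimated change is a 1.1-fold higher number from compound 3 to compound 4 (0.04 log units; within the scatter).

For compound 4 the expected value is 18000 nM, with an estimated range of 9000 nM to 35000 nM.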

Compound 4, half-maximal inhibitory concentration: 17200 nM
Estimate against measurement, compound 4: 1.0-fold (0.02 log units) above; low and high end bracket the measured number.
By their numbers in this assay, from the lowest: compounds 2, 3, 4 and 1 (each within the scatter of the next, the first and the last beyond it).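

In this assay, the change from pentyl to isopentyl, two bonds along the chain from a saturated ring carbon, gives a 1.1-fold higher number from compound 3 to compound 4 (0.02 log units; within the scatter), so this direct comparison finds no effect of this branch that can be told from the scatter. Compound 4 also provides two other single-change comparisons: methyl in place of hydrogen on the chain gives a 1.4-fold higher number from compound 2 to compound 4 (0.16 log units; within the scatter), and trifluoromethyl in place of chloro on an aromatic carbon gives a 1.5-fold lower number from compound 1 to compound 4 (0.16 log units; within the scatter), and both steps also lie within the scatter. No measurement shown here offers an explanation for these small differences.

From the compounds shown here alone, all four compounds carry plain hydrocarbon chains at this position, so it remains open whether an amine or a carboxylic acid on the chain, or a much longer chain, would give a step beyond the scatter. Going by these compounds, only chloro and trifluoromethyl appear on that aromatic carbon, so what a nitrile or a methoxy group would do there also remains open.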